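A few compounds are considered here, and "the series" means these few. Any claim that something is new, unique, unknown or untested is made for them only; others in the source may bear on it.

Measured so far in a functional assay on RAW264.7 cells (Mus musculus) for inhibition; a higher number here means a weaker inhibitor, a lower number a stronger inhibitor:
- compound 1 `O=C1/C(=C/c2ccccc2)CCc2ccc(O)cc21`: 710 nM
- compound 2 `O=C1/C(=C/c2ccc(C(F)(F)F)cc2)CCc2ccc(O)cc21`: only a limit of the assay, > 10000 nM

Compound 1 carries the only number shown in this assay; the other value is a limit. The step to compound 3 `O=C1/C(=C/c2cccc(Br)c2)CCc2ccc(O)cc21` is bromo in place of hydrogen on an aromatic carbon. Among the measured compounds shown here, one measured step bears on it: an at least 14-fold higher number from compound 1 to compound 2 (1.14 log units; beyond the scatter), with compound 2 sitting at the limit of > 10000 nM in this assay, at which 1 of the 2 values shown sits. That step puts a different group on a different aromatic carbon, so it is only a rough guide; a weakening is expected, likely smaller than that one. Compound 3 is expected to give 2000 nM (range 600 nM to 8000 nM). The expected step is a 2.8-fold higher number from compound 1 to compound 3 (0.45 log units; beyond the scatter).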

Compound 3, half-maximal inhibitory concentration: 480 nM
Compound 3: the middle estimate sits 4.2-fold (0.62 log units) above what was measured; measured number outside the range, below it.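

In this assay, bromo in place of hydrogen, meta to a large group, gives a 1.5-fold lower number from compound 1 to compound 3 (0.17 log units; within the scatter) and so leaves inhibition effectively unchanged. An added group on this six-membered aromatic ring therefore need not weaken inhibition, which the trifluoromethyl of compound 2 alone could not show. The value of compound 2 is a limit, not a number. On these data alone, whether its loss follows the trifluoromethyl group itself or its place on the ring stays open, as does the effect of an amine or a carboxylic acid where the bromo sits.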